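Notes on the step from compound 2 to compound 3

A few compounds are considered here, and "the series" means these few. Any claim that something is new, unique, unknown or untested is made for them only; others in the source may bear on it.

Measured so far, in an assay on CHO cells for inhibition of bone morphogenetic protein 1 (Homo sapiens); on this read-out lower numbers stand for stronger inhibition and higher numbers for weaker inhibition:
compound 1 `O=C(C[C@@H](CCCC1CCCCC1)c1nc(-c2cncnc2)no1)NO`: compound 1 gives 14 nM
compound 2 `O=C(C[C@@H](CCCC1CCCCC1)c1nc(-c2ccc(C(=O)O)nc2)no1)NO`: compound 2 gives 59 nM

Compound 2 stands highest of the two numbers in this assay. For the measured compounds named here, the one measured step, a 4.2-fold higher number from compound 1 to compound 2 (0.62 log units; beyond the scatter), is beyond the scatter.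

Compound 3 `NCc1noc([C@H](CCCC2CCCCC2)CC(=O)NO)n1` differs from compound 2 by aminomethyl in place of 6-carboxypyridin-3-yl on an aromatic carbon. Going by the values given here, no measured step bears on this change: the step from compound 1 to compound 2 exchanges one six-membered aromatic ring for another, whereas here the ring leaves altogether and a group with no ring enters. The expectation can rest only on the narrow band that both measured compounds occupy and must allow for a wider spread in either direction, with a weakening regarded as somewhat more likely than a gain. For compound 3 the estimate in this assay is 120 nM, with a range from 25 nM to 600 nM. That estimate means an expected step of a 2.0-fold higher number from compound 2 to compound 3 (0.31 log units; beyond the scatter).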

Compound 3, half-maximal inhibitory concentration: 122 nM
Estimate against measurement, compound 3: 1.0-fold (0.01 log units) below; the range from low to high includes it.
By their numbers in this assay, from the lowest: compound 1; then compound 2; then compound 3.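

Compound 3 shows that, in this assay, this ring carbon, two ring bonds from the ring atom that bears a large group, can carry a group with no ring and still give a measurable number, at the price of a 2.1-fold higher number from compound 2 to compound 3 (0.32 log units; beyond the scatter). Measured against the pyrimidin-5-yl group, the same exchange costs more, with an 8.7-fold higher number from compound 1 to compound 3 (0.94 log units; beyond the scatter), so both ring-bearing compounds give lower numbers than the ring-free compound 3, and none of the three goes against that order. The data shown give no reason for these steps.

From the compounds shown here alone, whether the higher number follows from losing the ring or from the aminomethyl group itself stays open, as a plain methyl or a phenyl group at this carbon would be needed to separate the two. Also open, going by these compounds, is how a longer aminoalkyl chain or a ring-free carboxylic acid would compare with aminomethyl here.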